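A few compounds are considered here, and "the series" means these few. Any claim that something is new, unique, unknown or untested is made for them only; others in the source may bear on it.

Among the compounds with values here, compound 2 `O=S(=O)(c1ccccc1)c1nc2ccccc2nc1Nc1ccc(Cl)cc1` gives 15300 nM in a functional assay on PC-3 cells (Homo sapiens) for cytotoxicity, read by MTT assay, with a stated time of 72 h (a lower number here means a stronger inhibitor, a higher number a weaker inhibitor), the highest of the two numbers measured so far. Compound 1 `COc1cc(Nc2nc3ccccc3nc2S(=O)(=O)c2ccccc2)cc(OC)c1` gives 140 nM in this assay. Within the data shown here, the only measured step, a 110-fold higher number from compound 1 to compound 2 (2.04 log units; beyond the scatter), changed the group on the nitrogen and left the phenyl untouched. Compound 3 `O=S(=O)(c1ccc(Br)cc1)c1nc2ccccc2nc1Nc1ccc(Cl)cc1` differs from compound 2 by bromo in place of hydrogen on an aromatic carbon. Among the measured compounds shown here, no measured step touches that phenyl, so nothing known bears directly on this change, and no step beyond the scatter is expected. Compound 3 is therefore expected to give about 15000 nM in this assay, within 5000 nM to 45000 nM, an expected step of a 1.0-fold lower number from compound 2 to compound 3 (0.01 log units; within the scatter).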

Compound 3, half-maximal inhibitory concentration: 7460 nM
Compound 3: middle estimate off by 2.0-fold (0.30 log units), on the high side; low and high end bracket the measured number.
By their numbers in this assay, from the lowest: compound 1; then compound 3; then compound 2.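

In this assay, within the data shown here, the phenyl that no earlier step had touched proves able to move the number: 4-bromophenyl in place of phenyl gives a 2.1-fold lower number from compound 2 to compound 3 (0.31 log units; beyond the scatter). This step is modest, far smaller than a 110-fold higher number from compound 1 to compound 2 (2.04 log units; beyond the scatter), but it shows that this ring is not silent. Nothing measured here explains the change.

Only bromo is shown at this place, so it remains open whether an amine or a carboxylic acid on the same carbon would shift the number. On these data alone, it is also open whether the step would hold with the 3,5-dimethoxyphenyl of compound 1 on the nitrogen.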